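The source may hold more compounds than are shown below. What is called first, only, known or untested is meant among the compounds shown, and "the series" means these compounds.

Working notes on a small nitropyrrole series in an ADME assay on Vero cells (Chlorocebus sabaeus) for cytotoxicity, read by MTT assay, with a stated time of 72 h; on this read-out lower numbers stand for stronger inhibition and higher numbers for weaker inhibition. Compound 1 `O=C(NNC(=S)NC1CCCCC1)c1cc([N+](=O)[O-])c[nH]1` carries a thiosemicarbazide tail and an unsubstituted ring nitrogen; in this assay compound 1 gives 204000 nM. Compound 3 `Cn1cc([N+](=O)[O-])cc1C(=O)NNC(=S)NC1CCCCC1` keeps the same tail with a methyl on the ring nitrogen, and in this assay compound 3 gives 352000 nM. The change from compound 3 to compound 1 is hydrogen in place of methyl on an aromatic nitrogen, and it made a 1.7-fold lower number from compound 3 to compound 1 (0.24 log units; within the scatter). Compound 2 `COc1ccc(NC(=O)NNC(=O)c2cc([N+](=O)[O-])cn2C)cc1` belongs to the semicarbazide branch, methylated on the ring nitrogen; in this assay compound 2 gives 328000 nM. The difference between the core of compound 2 and the core of compound 3 is not broken down here; the two values sit close together, within the scatter of each other, so no order between compound 2 and compound 3 can be read from them.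

Compound 4 `COc1ccc(NC(=O)NNC(=O)c2cc([N+](=O)[O-])c[nH]2)cc1` has not yet been measured. For the measured compounds named here, it relates to compound 2 by hydrogen in place of methyl on an aromatic nitrogen, the same change as the one from compound 3 to compound 1, at a place described in identical terms. Going by the values given here, the only guide is the measured pair, which moved within the scatter, so the expectation is a step of comparable size, a 1.5-fold lower number from compound 2 to compound 4 (0.17 log units; within the scatter), because compound 2 gives 328000 nM and the earlier pair showed a 1.7-fold lower number from compound 3 to compound 1 (0.24 log units; within the scatter). Compound 4 is therefore estimated at 220000 nM in this assay, with a range of 110000 nM to 450000 nM expected to cover most repeats.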

Compound 4, half-maximal inhibitory concentration: 401000 nM
Beside the measured number, compound 4's estimate is 1.8-fold (0.26 log units) below it, and the stated range covers the measured number.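

In this assay, hydrogen in place of methyl on an aromatic nitrogen gave a 1.2-fold higher number from compound 2 to compound 4 (0.09 log units; within the scatter) and, set beside the earlier step on the other core, the change does not separate the two cores: the same change on two cores in this assay, a 1.7-fold lower number (0.24 log units; within the scatter) from compound 3 to compound 1 and a 1.2-fold higher number (0.09 log units; within the scatter) from compound 2 to compound 4, 2.1-fold (0.32 log units) apart, within the scatter of two such steps. For the compounds shown here, each step and the gap between them lie within the scatter, so across these two cores the change leaves no step that can be told apart from repeat measurements, and no direction can be assigned to it. This does not show that the change is without effect in this series or that it would behave the same on a third core, and a small real step on either core could stay hidden within the scatter of just two pairs.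

Open, on these data alone, is whether a longer chain such as ethyl on the aromatic nitrogen, or a carboxylic acid in place of the nitro group, would give a number that stands clear of the scatter in this assay. Also open, as far as these compounds go, is what each part of the tail contributes on its own, as the cyclohexyl thiosemicarbazide tail and the methoxyphenyl semicarbazide tail differ in more than one place.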